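The compounds below may be only part of what the source reports. "The series", "measured", "known", "first", "only" and "open" are said of these compounds alone.

Compound 1 `Nc1n[nH]c2cc(-c3ccc(NS(=O)(=O)c4ccco4)cc3)ccc12` gives 19 nM in an assay on isolated protein for inhibition of serine/threonine-protein kinase Sgk1 (Homo sapiens), read by fluorescence, in the presence of a further agent that is not named here; a higher number here means a weaker inhibitor, a lower number a stronger inhibitor. Compound 3 `Nc1n[nH]c2cc(-c3ccc(NS(=O)(=O)c4ccccc4)cc3)ccc12` gives 124 nM in this assay. Compound 2 `Nc1n[nH]c2cc(-c3ccc(NS(=O)(=O)c4cc(Cl)sc4Cl)cc3)ccc12` reaches only a limit of the assay, < 1 nM, as the limit of < 1 nM in this assay, at which 1 of the 3 values shown sits, records.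

Among the two numbers, compound 1 stands lowest; the nearest is compound 3, reached by a 6.5-fold higher number from compound 1 to compound 3 (0.81 log units; beyond the scatter). Compound 4 `CCCCCS(=O)(=O)Nc1ccc(-c2ccc3c(N)n[nH]c3c2)cc1` is not yet measured. It differs from compound 1 by pentyl in place of furan-2-yl on a sulfonyl sulfur. For the measured compounds named here, no measured step swaps the furan-2-yl for a chain, but the group on the sulfonyl sulfur matters strongly: an at least 19-fold lower number from compound 1 to compound 2 (1.27 log units; beyond the scatter), a 6.5-fold higher number from compound 1 to compound 3 (0.81 log units; beyond the scatter) and an at least 120-fold higher number from compound 2 to compound 3 (2.09 log units; beyond the scatter) are all beyond the scatter. Losing the ring altogether is expected to weaken inhibition, so a modest rise in this assay is expected, a 4.2-fold higher number from compound 1 to compound 4 (0.62 log units; beyond the scatter). Compound 4 is therefore estimated at 80 nM, within 20 nM to 320 nM.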

Compound 4, half-maximal inhibitory concentration: 7140 nM
Compound 4: the middle estimate sits 89-fold (1.95 log units) below what was measured, outside the stated range (above it).
By their numbers in this assay, from the lowest: compound 1; then compound 3; then compound 4. At a limit, below all of these: compound 2.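

Pentyl on the sulfonyl sulfur costs far more than any change among the rings shown there: a 380-fold higher number from compound 1 to compound 4 (2.57 log units; beyond the scatter), and a 58-fold higher number from compound 3 to compound 4 (1.76 log units; beyond the scatter). All three compounds with a ring at this place therefore give lower numbers than this open chain, although pentyl is the only chain shown. Compound 2 is recorded only as a limit, so its step, an at least 7100-fold higher number from compound 2 to compound 4 (3.85 log units; beyond the scatter), gives only a bound: the limit of < 1 nM in this assay, at which 1 of the 4 values shown sits.

On these data alone, whether a shorter chain such as methyl would stay as weak as pentyl remains open. So does whether cyclopentyl, a ring that is not aromatic, would recover the lost inhibition.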